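From Trifluoromethyl to Methoxy on a Benzyl Group

The source may hold more compounds than are shown below. What is called first, only, known or untested is meant among the compounds shown, and "the series" means these compounds.

Measured so far in a functional assay on Jurkat cells (Homo sapiens) for inhibition, read by CCK-8 assay, with a stated time of 48 h; on this read-out lower numbers stand for stronger inhibition of growth and higher numbers for weaker inhibition of growth
- Compound 1 `Cc1ccccc1Nc1nc(Nc2ccc(N3CCN(C)CC3)cn2)ncc1Cl` gives 8080 nM
- Compound 2 `CN1CCN(c2ccc(Nc3ncc(Cl)c(NCc4ccc(C(F)(F)F)cc4)n3)nc2)CC1` gives 7960 nM

Compound 2 stands level with compound 1, so neither can be ranked above the other. Compound 3 `COc1ccc(CNc2nc(Nc3ccc(N4CCN(C)CC4)cn3)ncc2Cl)cc1` differs from compound 2 in one place, with methoxy in place of trifluoromethyl on an aromatic carbon, which turns 4-(trifluoromethyl)benzyl into 4-methoxybenzyl (methoxy in place of trifluoromethyl on an aromatic carbon). Going by the values given here, only one measured step bears on this change, and it is a 1.0-fold lower number from compound 1 to compound 2 (0.01 log units; within the scatter) where 4-(trifluoromethyl)benzyl took the place of 2-methylphenyl on a nitrogen. Among the compounds with values here, no measured compound carries methoxy, so this guide is thin. In this assay no step beyond the scatter is therefore expected, in either direction. The estimate is a 1.1-fold lower number from compound 2 to compound 3 (0.03 log units; within the scatter) as the expected step. Compound 3 is expected at 7500 nM (estimated range 3800 nM to 14000 nM).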

Compound 3, concentration for 50% growth inhibition: 12900 nM
Compound 3: the middle estimate sits 1.7-fold (0.24 log units) below what was measured, and the stated range covers the measured number.
By their numbers in this assay, from the lowest: compounds 2, 1 and 3 (each within the scatter of the next).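

In this assay, the benzyl group now carries a second kind of substituent, and methoxy in place of trifluoromethyl gives a 1.6-fold higher number from compound 2 to compound 3 (0.21 log units; within the scatter), so this exchange of one group for another, para to a large group, does not separate the two compounds. Placing 4-methoxybenzyl in place of 2-methylphenyl on the nitrogen gives a 1.6-fold higher number from compound 1 to compound 3 (0.20 log units; within the scatter), which means that compound 1, compound 2 and compound 3 all stand level and cannot be ranked against one another. Nothing at hand explains the size of either step.

Open, going by these compounds, is whether any group at this place can move the number beyond the scatter at all. An amine or a carboxylic acid on the ring, or a longer chain on the nitrogen, would test this.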